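A few compounds are considered here, and "the series" means these few. Any claim that something is new, unique, unknown or untested is made for them only; others in the source may bear on it.

The measured compounds and their values in a functional assay on the whole organism (stomach) for inhibition, with Rattus norvegicus as the target, at a dose of 100 mg/kg by the intraduodenal route; on this read-out higher numbers stand for more inhibition at the one dose given (going by the name of the read-out) and lower numbers for less inhibition:

compound 1, `Cc1ccc(=O)n(CCCCCC(=N)S)n1`, gives 36.6%
compound 2, `CC(CC(=N)S)n1nc(-c2ccccc2)ccc1=O`, gives 15.5%
compound 3, `N=C(S)CCCCCn1nc(-c2ccccc2)ccc1=O`, gives 91.4%

Compound 3 and compound 1 differ in one place only, (methyl in place of phenyl on an aromatic carbon), and this change made a step of a number 54.8 percentage points lower from compound 3 to compound 1 (beyond the scatter). Compound 4, `Cc1ccc(=O)n(C(C)CC(=N)S)n1`, has not yet been measured; it arises from compound 2 by methyl in place of phenyl on an aromatic carbon. Among the measured compounds shown here, this is the same kind of change as the one from compound 3 to compound 1, though not the same: around the place of the change, the ring carbon is meta to a group of 8 heavy atoms in compound 3, but meta to a group of 6 heavy atoms in compound 2. The difference between the cores of compound 2 and compound 3 is not broken down here.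

Compound 2 already stands at the bottom of the three measured numbers. A step as large as the earlier one cannot repeat downward from there, so the expectation for compound 4 is a modest drop of a number 9.5 percentage points lower from compound 2 to compound 4 (within the scatter), resting on the direction of a number 54.8 percentage points lower from compound 3 to compound 1 (beyond the scatter). Compound 4 is therefore estimated at 6%, between 0% and 25%.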

Compound 4, a percentage reported as inhibition, in the whole organism at one dose (the size of the read-out at that dose, not a potency): 32.5%
Compound 4: the middle estimate sits 26.5 percentage points below what was measured; the measured number lies above the stated range.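

In this assay, putting methyl in place of phenyl on the aromatic carbon gave a number 17 percentage points higher from compound 2 to compound 4 (beyond the scatter). Set beside the earlier step, this shows that the change does not carry over from one core to the other with the same size, or even the same direction: the same change on two cores in this assay, a number 54.8 percentage points lower (beyond the scatter) from compound 3 to compound 1 and a number 17 percentage points higher (beyond the scatter) from compound 2 to compound 4, 71.8 percentage points apart, beyond the scatter of two such steps

This does not explain why the two steps part ways, since the difference between the two cores is not broken down here, and two pairs are too few to predict what the same change would do on a third core. The compounds shown leave open what other groups on that aromatic carbon, such as ethyl, cyclohexyl or a chlorine atom, would do on either core. They also leave open whether a carboxylic acid or an amine at the end of the chain, in place of the present end group, would change the reading at this dose.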